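The compounds below may be only part of what the source reports. "The series", "measured", "known", "first", "only" and "open" are said of these compounds alone.

Measured so far in a functional assay on PC-3 cells (Homo sapiens) for cytotoxicity, read by sulforhodamine B assay, with a stated time of 48 h; on this read-out lower numbers stand for stronger inhibition and higher numbers for weaker inhibition:
compound 1 `CC(=O)N1N=C(c2ccco2)CC1c1ccc([N+](=O)[O-])cc1`: 21300 nM
compound 2 `CC(=O)N1N=C(c2ccco2)CC1c1ccc(Br)cc1`: 42100 nM
compound 3 `CC(=O)N1N=C(c2ccco2)CC1c1ccc(Cl)cc1`: 39000 nM

Compound 3 lies within the scatter of both other compounds: a 1.8-fold higher number from compound 1 to compound 3 (0.26 log units; within the scatter) and a 1.1-fold lower number from compound 2 to compound 3 (0.03 log units; within the scatter). Next is compound 4 `CC(=O)N1N=C(c2ccco2)CC1c1ccc(N(C)C)cc1`, with dimethylamino in place of chloro on an aromatic carbon. All three measured steps exchange a group on an aromatic carbon. The third, a 2.0-fold higher number from compound 1 to compound 2 (0.30 log units; within the scatter), also stays within the scatter in this assay. Going by the values given here, none of the measured compounds carries dimethylamino, so the range is kept wide. No step beyond the scatter is expected. For compound 4 the estimated value is 30000 nM, with an expected range of 12000 nM to 75000 nM. The expected step is a 1.3-fold lower number from compound 3 to compound 4 (0.11 log units; within the scatter).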

Compound 4, half-maximal inhibitory concentration: 16700 nM
Estimate against measurement, compound 4: 1.8-fold (0.25 log units) above; measured number inside the range.
By their numbers in this assay, from the lowest: compounds 4, 1, 3 and 2 (each within the scatter of the next, the first and the last beyond it).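

In this assay, dimethylamino at this aromatic carbon gives steps beyond the scatter, unlike the exchanges among nitro, bromo and chloro, though both are modest: a 2.3-fold lower number from compound 3 to compound 4 (0.37 log units; beyond the scatter) and a 2.5-fold lower number from compound 2 to compound 4 (0.40 log units; beyond the scatter). Against nitro the exchange stays within the scatter, a 1.3-fold lower number from compound 1 to compound 4 (0.11 log units; within the scatter), so the two groups cannot be told apart here. Nothing available accounts for these steps. Still open, from the compounds shown here alone, is whether a primary amine or a carboxylic acid on this carbon would move the number further, and how diethylamino would compare with dimethylamino.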